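A few compounds are considered here, and "the series" means these few. Any claim that something is new, unique, unknown or untested is made for them only; others in the source may bear on it.

For the measured compounds named here, in a functional assay on DU-145 cells (Homo sapiens) for cytotoxicity, read by sulforhodamine B assay, with a stated time of 48 h (a lower number here means a stronger inhibitor, a higher number a weaker inhibitor), compound 2 `CC(=O)OC[C@H]1O[C@@H](n2cc(CN3C(=O)/C(=C/c4cccs4)c4ccccc43)nn2)[C@H](OC(C)=O)[C@@H](OC(C)=O)[C@@H]1OC(C)=O` gives 23400 nM, the higher of the two numbers measured so far; compound 1 `CC(=O)OC[C@H]1O[C@@H](n2cc(CN3C(=O)/C(=C/c4ccc(C)cc4)c4ccccc43)nn2)[C@H](OC(C)=O)[C@@H](OC(C)=O)[C@@H]1OC(C)=O` gives 9300 nM. Going by the values given here, the single measured step, a 2.5-fold higher number from compound 1 to compound 2 (0.40 log units; beyond the scatter), exchanged one aromatic group for another on the same carbon. Among the compounds with values here, compound 3 `CCC/C=C1/C(=O)N(Cc2cn([C@@H]3O[C@H](COC(C)=O)[C@@H](OC(C)=O)[C@H](OC(C)=O)[C@H]3OC(C)=O)nn2)c2ccccc21` differs from compound 2 by propyl in place of thiophen-2-yl on a double-bonded chain carbon bound to a double-bonded ring carbon, an aromatic ring giving way to a short chain, which no measured step covers directly. Only a small change is therefore expected, roughly a 1.1-fold higher number from compound 2 to compound 3 (0.03 log units; within the scatter), with little in the data to anchor it. Compound 3 is estimated at 25000 nM, within a range from 8000 nM to 80000 nM.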

Compound 3, half-maximal inhibitory concentration: 19700 nM
The estimate for compound 3 lay 1.3-fold (0.10 log units) above the measured number; low and high end bracket the measured number.
By their numbers in this assay, from the lowest: compound 1; then compounds 3 and 2 (each within the scatter of the next).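

On a double-bonded chain carbon bound to a double-bonded ring carbon, an aromatic ring is not required to hold the number of compound 2: propyl in place of thiophen-2-yl brings a 1.2-fold lower number from compound 2 to compound 3 (0.07 log units; within the scatter) and leaves the two indistinguishable. The same propyl in place of 4-methylphenyl brings a 2.1-fold higher number from compound 1 to compound 3 (0.33 log units; beyond the scatter), so among these three groups only 4-methylphenyl stands apart. No evidence on the cause is at hand. From the compounds shown here alone, whether a longer chain, an unsubstituted phenyl or an amine-bearing group at this place would match compound 1 remains open.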